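Solubility notes: varying the aryl group on the shared core

The source may hold more compounds than are shown below. What is called first, only, known or untested is meant among the compounds shown, and "the series" means these compounds.

Within the data shown here, compound 2 `COc1cccc(CNCCCNc2ccnc3cc(Oc4ccc(C(C)(C)C)cc4)ccc23)c1O` gives 14500 nM in a physicochemical assay for solubility, with a stated time of 18 h, at pH 7.4 (on this read-out lower numbers stand for lower solubility and higher numbers for higher solubility), the lower of the two numbers so far; compound 1 `COc1cccc(CNCCCNc2ccnc3cc(-c4ccccc4)ccc23)c1O` gives 32000 nM. Among the measured compounds shown here, the single measured step, a 2.2-fold lower number from compound 1 to compound 2 (0.34 log units; beyond the scatter), is the only guide. Compound 3 `COc1cccc(CNCCCNc2ccnc3cc(-c4ccc(C(F)(F)F)cc4)ccc23)c1O` carries 4-(trifluoromethyl)phenyl in place of 4-(tert-butyl)phenoxy on an aromatic carbon. That change removes the phenoxy feature that set compound 2 apart from compound 1, yet introduces a trifluoromethyl group present in neither measured compound. The expected step is a 1.4-fold higher number from compound 2 to compound 3 (0.14 log units; within the scatter), within the scatter. Compound 3 is therefore estimated at 20000 nM, with a range from 8000 nM to 50000 nM.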

Compound 3, solubility: 32000 nM
Compound 3: middle estimate off by 1.6-fold (0.20 log units), on the low side; measured number inside the range.
By their numbers in this assay, from the lowest: compound 2; then compounds 1 and 3 (each within the scatter of the next).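

In this assay the read-out at this aromatic carbon moves back up with a 2.2-fold higher number from compound 2 to compound 3 (0.34 log units; beyond the scatter) when 4-(trifluoromethyl)phenyl replaces 4-(tert-butyl)phenoxy. Trifluoromethyl in place of hydrogen on an aromatic carbon gives no change at the digits printed from compound 1 to compound 3 (within the scatter) and leaves compound 2 as the only one of the three set apart from the others. Nothing available gives a reason for either step. The compounds shown do not separate the phenoxy oxygen from the tert-butyl group in compound 2. Going by these compounds, how an amine or a carboxylic acid on the aryl ring would read here remains open.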